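Ester to acid on a biaryl amide in a cell assay

This account rests on a few compounds, and the source may have more. Where it says the series, first, only, none or still open, it means among the compounds named here.

Compound 1 `CCOC(=O)[C@H](CCSC)NC(=O)c1ccc(CNCc2c[nH]cn2)cc1-c1ccccc1C` is the only one of the three measured compounds that returns a number: in a functional assay on NIH3T3 cells (Mus musculus) (on this read-out lower numbers stand for an effect already at smaller amounts and higher numbers for an effect only at larger amounts of compound), compound 1 gives 10 uM. Compound 2 `CSCC[C@H](NC(=O)c1ccc(NCc2cncn2Cc2ccc(C)cc2)cc1-c1ccccc1)C(=O)O` gives only a limit of the assay, > 10 uM. Compound 3 `N#Cc1ccc(Cn2cncc2CNc2ccc(C(=O)Nc3cccc([N+](=O)[O-])c3)c(-c3ccccc3)c2)cc1` likewise reaches only a limit, > 10 uM. Two of three values therefore end at the limit of > 10 uM in this assay, at which 2 of the 3 values shown sit. Compound 4 `CSCC[C@H](NC(=O)c1ccc(CNCc2c[nH]cn2)cc1-c1ccccc1C)C(=O)O` has not been measured yet; it differs from compound 1 in one place, (hydrogen in place of ethyl on an oxygen next to a carbonyl group), so that ethoxycarbonyl becomes carboxy. Among the compounds with values here, no measured pair isolates this change, and the only other carboxy compound, compound 2, carries a different linker. The step in this assay from compound 1 to compound 4 is expected to be modest and toward larger amounts, a 2.0-fold higher number from compound 1 to compound 4 (0.30 log units; within the scatter). Compound 4 is estimated at 20 uM, between 6 uM and 60 uM.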

Compound 4, concentration for half-maximal effect: > 25 uM
Compound 4: only a limit was reported; the forecaster's own chance of this, stated with the estimate: 55%; middle value at least 1.2-fold (0.09 log units) away from the limit.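

With the rest of compound 1 unchanged, ethoxycarbonyl to carboxy can now be read as a single change: in this assay it gives an at least 2.5-fold higher number from compound 1 to compound 4 (0.39 log units; beyond the scatter). At this position, then, hydrogen in place of ethyl moves the read-out beyond the scatter, toward larger amounts of compound. The result for compound 4 is only a limit of the assay: the limit of > 25 uM in this assay, at which 1 of the 4 values shown sits.

As far as these compounds go, how far compound 4 truly lies from compound 1 stays open. So does whether a methyl ester or a primary carboxamide in place of ethoxycarbonyl would keep the read-out of compound 1.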